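This account rests on a few compounds, and the source may have more. Where it says the series, first, only, none or still open, it means among the compounds named here.

Compounds measured:
compound 1 `Nc1sc(-c2ccccc2)c(-c2cccc(C(F)(F)F)c2)c1C(=O)c1ccccc1` gives 82.4% in an assay on CHO-K1 cells for displacement of a labelled ligand from adenosine receptor A1 (Homo sapiens), tested at 10 uM; on this read-out higher numbers stand for more inhibition at the one concentration tested (going by the name of the read-out) and lower numbers for less inhibition
compound 2 `Nc1sc(-c2ccc([N+](=O)[O-])cc2)c(-c2cccc(C(F)(F)F)c2)c1C(=O)c1ccccc1` gives 34.8% in this assay
compound 3 `CCOC(=O)c1c(N)sc(-c2ccccc2)c1-c1cccc(C(F)(F)F)c1` gives 83.6% in this assay

Compound 3 stands at the top of the three numbers in this assay; its nearest neighbour is compound 1, with a step of a number 1.2 percentage points higher from compound 1 to compound 3 (within the scatter) that is within the scatter, so the two cannot be ordered; compound 2 is furthest away. Compound 4 `CCOC(=O)c1c(N)sc(-c2ccc(Cl)cc2)c1-c1cccc(C(F)(F)F)c1` has not yet been measured. The change from compound 3 to compound 4 is chloro in place of hydrogen on an aromatic carbon, on an aromatic carbon of a six-membered aromatic ring of carbon only, para to a large group. For the measured compounds named here, the one measured step that bears on it is the substitution at the same ring in the step from compound 1 to compound 2, where a nitro group in place of hydrogen brought a number 47.6 percentage points lower from compound 1 to compound 2 (beyond the scatter), a large drop. Chloro is a different group, so the size of the effect is uncertain, but a drop beyond the scatter is expected, smaller than the nitro case. The estimated step is a number 25.6 percentage points lower from compound 3 to compound 4 (beyond the scatter). Compound 4 is therefore expected to give about 58%, in a range from 35% to 82%.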

Compound 4, a percentage reported as inhibition, at one concentration (the size of the read-out at that concentration, not a potency): 58.4%
Compound 4: the middle estimate sits 0.4 percentage points below what was measured; the range from low to high includes it.
By their numbers in this assay, from the lowest: compound 2; then compound 4; then compounds 1 and 3 (each within the scatter of the next).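

In this assay, going from phenyl to 4-chlorophenyl gives a number 25.2 percentage points lower from compound 3 to compound 4 (beyond the scatter), so the loss beyond the scatter seen earlier at this ring with nitro, a number 47.6 percentage points lower from compound 1 to compound 2 (beyond the scatter), is not limited to that one group. Chloro, a single chlorine atom, also lowers the number at this place, and it does so on the ethoxy carbonyl compounds, whereas the earlier step stood on the phenyl carbonyl compounds. Nothing available here accounts for the drop.

The compounds shown leave open whether an amine, a methoxy group or a carboxylic acid at this place would lower the number as well. They also leave open how chloro would behave on the phenyl carbonyl compounds, or elsewhere on this ring.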